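The source may hold more compounds than are shown below. What is called first, only, known or untested is meant among the compounds shown, and "the series" means these compounds.

Compound 1 `COc1cccc(-c2nc3cc(C)ccc3c(=O)[nH]2)c1` stands at the top of the three measured compounds in an assay on isolated protein for inhibition of DNA topoisomerase 1 (Homo sapiens), with a stated time of 30 min, tested at 20 uM (a higher number here means a stronger effect of the compound at the concentration tested, a lower number a weaker effect), giving 80%. Compound 3 `CCN(CC)c1ccc2nc(-c3ccccc3C(F)(F)F)[nH]c(=O)c2c1` gives 13.3% in this assay, and compound 2 `CCN(CC)c1ccc2nc(-c3ccccc3N(C)C)[nH]c(=O)c2c1` gives 0%; both lie far below compound 1 by steps beyond the scatter, so compound 1 is the strongest of the three on the numbers shown.

The unmeasured compound 4 `Cc1ccc2c(=O)[nH]c(-c3cccc(C(F)(F)F)c3)nc2c1` keeps the core of compound 1 and differs from it in one place: trifluoromethyl in place of methoxy on an aromatic carbon.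

For the measured compounds named here, only one measured step bears on this change. Compounds 2 and 3 share a different core, and there a number 13.3 percentage points higher from compound 2 to compound 3 (beyond the scatter). That step also ends in trifluoromethyl, but it starts from dimethylamino rather than methoxy, and from a compound with almost no inhibition, so it is a weak guide. Going by the values given here, nothing among the measured compounds shows methoxy giving way to trifluoromethyl on the core of compound 1. The expectation is therefore uncertain, with a small step in either direction the most likely outcome and little change beyond the scatter.

Compound 4 is expected to give 65% in this assay, within a range from 35% to 90%. This estimate means a number 15 percentage points lower from compound 1 to compound 4 (beyond the scatter), a step expected to be modest at most.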

Compound 4, a percentage reported as inhibition, at one concentration (the size of the read-out at that concentration, not a potency): 93.6%
Estimate against measurement, compound 4: 28.6 percentage points below; measured number outside the range, above it.
By their numbers in this assay, from the lowest: compound 2; then compound 3; then compound 1; then compound 4.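

On the core of compound 1, the aromatic carbon that carries methoxy also tolerates trifluoromethyl in this assay: the exchange gives a number 13.6 percentage points higher from compound 1 to compound 4 (beyond the scatter), so inhibition does not depend on the oxygen of methoxy, the one hydrogen-bond acceptor that leaves with this change. The earlier step, a number 13.3 percentage points higher from compound 2 to compound 3 (beyond the scatter), also ended in trifluoromethyl, but it started from dimethylamino on a different core and reached only a weak result, with compound 3 at 13.3%, whereas this step shows trifluoromethyl in a strongly inhibiting compound. The two steps point the same way, yet they start from different groups on different cores, and no measurement shown explains the rise seen with this change.

The compounds shown leave open whether other groups at this same place, such as a chlorine atom, a nitrile or a hydroxyl, would match trifluoromethyl, and whether trifluoromethyl would do as well on another carbon of the same ring. They also leave open how potent compound 4 is, since its read-out comes from one concentration and is not a measure of potency.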